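Halogen Swap on the Anilide Ring: Compound 3 to Compound 4

The source may report more compounds than this note shows. Statements on the series, on what has been measured and on what is new or still open speak of the compounds shown alone.

Compound 1 `O=C(NC(=S)Nc1ccc(F)cc1)c1cn(-c2ccccc2)nc1-c1ccccc1`: 4210 nM
Compound 2 `COc1ccc(-c2nn(-c3ccccc3)cc2C(=O)NC(=S)Nc2ccc(F)cc2)cc1`: 3050 nM
Compound 3 `O=C(NC(=S)Nc1ccc(Cl)cc1)c1cn(-c2ccccc2)nc1-c1ccc(F)cc1`: 3090 nM

In a functional assay on NCI-H460 cells (Homo sapiens) for inhibition, read by CCK-8 assay, with a stated time of 48 h (a higher number here means a weaker inhibitor, a lower number a stronger inhibitor), compound 1 gives 4210 nM, compound 2 gives 3050 nM and compound 3 gives 3090 nM. Compound 3 stands second highest of the three numbers; compound 2 is nearest and compound 1 furthest, and both gaps lie within the scatter, so no order can be read among the three. Among the compounds with values here, the only step between neighbours that differ in one place is a 1.4-fold lower number from compound 1 to compound 2 (0.14 log units; within the scatter), which concerns the other phenyl ring of the shared core.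

Compound 4 `O=C(NC(=S)Nc1ccc(F)cc1)c1cn(-c2ccccc2)nc1-c1ccc(F)cc1` differs from compound 3 by fluoro in place of chloro on an aromatic carbon. Within the data shown here, no measured step bears directly on this change. Compound 1 and compound 3 differ in two places at once, and their two values lie within the scatter of each other, which gives no hint of a shift from the halogen on the anilide ring alone. Among the measured compounds shown here, the one known step sits elsewhere on the molecule and is itself within the scatter. The step of a 1.1-fold higher number from compound 3 to compound 4 (0.05 log units; within the scatter) is therefore expected to remain within the scatter, with no direction favoured. For compound 4 in this assay the estimate is 3500 nM, with a range from 1500 nM to 8000 nM.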

Compound 4, half-maximal inhibitory concentration: 3240 nM
Beside the measured number, compound 4's estimate is 1.1-fold (0.03 log units) above it, and the stated range covers the measured number.
By their numbers in this assay, from the lowest: compounds 2, 3, 4 and 1 (each within the scatter of the next).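

In this assay, within the data shown here, the change from 4-chlorophenyl to 4-fluorophenyl gives a 1.0-fold higher number from compound 3 to compound 4 (0.02 log units; within the scatter), and this is the first direct reading of the halogen on the anilide ring, which the earlier pair of compound 1 and compound 3 could not give since those two differ in two places at once. Compound 4 also extends what is known about the other phenyl ring of the shared core: fluoro in place of hydrogen gives a 1.3-fold lower number from compound 1 to compound 4 (0.11 log units; within the scatter) and fluoro in place of methoxy gives a 1.1-fold higher number from compound 2 to compound 4 (0.03 log units; within the scatter), so all three exchanges leave the number within the scatter and, among these compounds, neither ring shows a change that can be read. Nothing available bears on why these numbers lie so close together. The compounds shown carry only chloro or fluoro on the anilide ring, so it stays open whether that position would respond to a group of another kind, such as an amine, a carboxylic acid or a longer chain. Among these compounds, the same question holds for the other phenyl ring, where hydrogen, methoxy and fluoro are the only groups seen and a group such as a nitrile or a trifluoromethyl has no reading here.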